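A few compounds are considered here, and "the series" means these few. Any claim that something is new, unique, unknown or untested is made for them only; others in the source may bear on it.

Compound 1, `O=c1[nH]c(=O)n([C@@H]2O[C@H](COP(=O)(O)OP(=O)(O)OP(=O)(O)O)[C@@H](O)[C@H]2O)cc1Br`, gives 347 nM in an in vitro functional assay on 1321-N1 cells for agonist activity at P2Y purinoceptor 2 (Homo sapiens); on this read-out higher numbers stand for an effect only at larger amounts of compound and lower numbers for an effect already at smaller amounts.
Compound 2, `CCCc1cc(=O)n([C@@H]2O[C@H](COP(=O)(O)OP(=O)(O)OP(=O)(O)O)[C@@H](O)[C@H]2O)c(=O)[nH]1`, gives > 1000 nM in this assay.

Two measured compounds stand here, and only one of them has a number. Compound 1 gives a value in this assay. Among the compounds with values here, for compound 2 the read-out is a limit of this assay and not a number, as the line the limit of > 1000 nM in this assay, at which 1 of the 2 values shown sits, shows, so compound 2 stands at the weak end of what this assay reports, and no step between compound 1 and compound 2 can be sized.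

Compound 3, `CCCc1cc(=O)n([C@@H]2O[C@H](COP(=O)(O)OP(=O)(O)O)[C@@H](O)[C@H]2O)c(=O)[nH]1`, is compound 2 with one change: a hydrogen atom in place of a group of 4 heavy atoms (3 oxygen, 1 phosphorus; no ring), on an oxygen. Within the data shown here, no measured pair in this set carries a step of this kind, so the size of the step can only be estimated from where compound 2 stands.

The step from compound 2 to compound 3 in this assay is expected to be a step that the limit leaves unreadable from compound 2 to compound 3, that is toward higher numbers, larger than the usual scatter, and most likely again ending in a limit rather than a number. Compound 3 is therefore estimated at 6000 nM, within a range of 1500 nM to 40000 nM, in this assay.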

Compound 3, half-maximal effective concentration: > 100000 nM
Compound 3 gave a limit, no number; the forecaster's own chance of this, stated with the estimate: 85%; middle value at least 16-fold (1.22 log units) away from the limit.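

In this assay compound 3 gives > 100000 nM, which is a limit of the assay and not a number. Within the data shown here, compound 2 also stands at a limit, > 1000 nM, so no step between compound 2 and compound 3 can be read. The compounds shown leave open what a hydrogen atom in place of the group of 4 heavy atoms does to the read-out, in size or in direction.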